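The source may hold more compounds than are shown below. What is called first, only, known or untested is meant among the compounds shown, and "the series" means these compounds.

Three compounds built on one shared core have been examined in an assay on isolated protein for inhibition of alpha-mannosidase (Canavalia ensiformis), tested at 1000 uM; on this read-out lower numbers stand for less inhibition and higher numbers for more inhibition at the one concentration tested (going by the name of the read-out). Compound 1 `OC[C@]1(c2ccc(F)cc2)NC[C@H](O)[C@H]1O` gives 6.6% in this assay. Compound 2 `OC[C@@]1(c2c(F)c(F)c(F)c(F)c2F)NC[C@@H](O)[C@@H]1O` gives 0%, and compound 3 `COc1ccc([C@@]2(CO)NC[C@H](O)[C@H]2O)cc1OC` gives 0%. Compound 3 therefore matches compound 2 at the digits reported, and its gap to compound 1 lies within the usual scatter of repeated measurements, so none of the three can be told apart on these numbers; all sit at a level where no inhibition beyond the scatter is seen.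

Compound 4 `COc1cccc([C@@]2(CO)NC[C@H](O)[C@H]2O)c1` is not yet measured. It differs from compound 3 in one place: hydrogen in place of methoxy on an aromatic carbon. For the measured compounds named here, no two measured compounds differ in a single place, so there is no measured step of this kind to lean on.

The step of a number 3 percentage points higher from compound 3 to compound 4 (within the scatter) is expected to be none beyond the scatter, because compound 3 gives 0% in this assay and that level is shared by its companions. Compound 4 is accordingly estimated at 3% in this assay, within a range from 0% to 15%.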

Compound 4, a percentage reported as inhibition, at one concentration (the size of the read-out at that concentration, not a potency): 0%
Beside the measured number, compound 4's estimate is 3 percentage points above it, and the stated range covers the measured number.
By their numbers in this assay, from the lowest: compounds 2, 3, 4 and 1 (each within the scatter of the next).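

Hydrogen in place of methoxy on this aromatic carbon, ortho to a methoxy group and para to a group of 9 heavy atoms, gives the only single-place step among the compounds shown: in this assay the result is no change at the digits printed from compound 3 to compound 4 (within the scatter). Since compound 3 already sat at the bottom of the read-out, the step can show only that taking away this methoxy group brings no inhibition beyond the scatter, not whether the group contributes anything. No independent measurement bears on this result.

The compounds shown leave open whether another group on this aromatic carbon, such as an amine or a carboxylic acid, would raise the number in this assay beyond the scatter. They also leave open what a hydroxyl group in place of the remaining methoxy group of compound 4 would do.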